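Anilino substituent swap on the pyrrolinone series

This account rests on a few compounds, and the source may have more. Where it says the series, first, only, none or still open, it means among the compounds named here.

Measured compounds in a functional assay on U2OS cells (Homo sapiens) for antiproliferative activity, read by MTT assay, with a stated time of 72 h; on this read-out lower numbers stand for stronger inhibition and higher numbers for weaker inhibition:
compound 1 `CCCCCOC1=C(C(=O)c2ccccc2)C(c2ccc(Br)cc2)N(CCCn2ccnc2)C1=O`: 9140 nM
compound 2 `NC1=C(C(=O)c2ccccc2)C(c2ccc(Br)cc2)N(CCCn2ccnc2)C1=O`: 149000 nM
compound 3 `O=C(C1=C(Nc2ccc(Cl)cc2)C(=O)N(CCCn2ccnc2)C1c1ccc(Br)cc1)c1ccccc1`: 22800 nM

Compound 3 gives the second highest of the three numbers. Its nearest neighbour is compound 1, a 2.5-fold higher number from compound 1 to compound 3 (0.40 log units; beyond the scatter); its furthest is compound 2, a 6.5-fold lower number from compound 2 to compound 3 (0.82 log units; beyond the scatter). The remaining step, a 16-fold higher number from compound 1 to compound 2 (1.21 log units; beyond the scatter), is large.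

Compound 4 `O=C(C1=C(Nc2ccc(OC(F)(F)F)cc2)C(=O)N(CCCn2ccnc2)C1c1ccc(Br)cc1)c1ccccc1` differs from compound 3 by trifluoromethoxy in place of chloro on an aromatic carbon. Among the compounds with values here, none of the measured steps touches this aromatic carbon; all three concern the group on the double-bonded ring carbon of the core. Within the data shown here, no step therefore bears directly on the change, and no shift beyond the scatter is expected in this assay.

Compound 4 is estimated at 18000 nM, range 7000 nM to 50000 nM, meaning an expected step of a 1.3-fold lower number from compound 3 to compound 4 (0.10 log units; within the scatter).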

Compound 4, half-maximal inhibitory concentration: 11500 nM
Estimate against measurement, compound 4: 1.6-fold (0.19 log units) above, and the stated range covers the measured number.
By their numbers in this assay, from the lowest: compounds 1, 4 and 3 (each within the scatter of the next, the first and the last beyond it); then compound 2.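

In this assay, trifluoromethoxy in place of chloro on the aromatic carbon stays within the scatter (a 2.0-fold lower number from compound 3 to compound 4 (0.30 log units; within the scatter)). Adding 4-(trifluoromethoxy)phenyl to the amine nitrogen still gives a large step (a 13-fold lower number from compound 2 to compound 4 (1.11 log units; beyond the scatter)), while (4-(trifluoromethoxy)phenyl)amino in place of pentyloxy stays within the scatter (a 1.3-fold higher number from compound 1 to compound 4 (0.10 log units; within the scatter)), unlike the (4-chlorophenyl)amino replacement in compound 3. No measured property is available to account for these steps.

Open, from the compounds shown here alone, is whether methoxy, nitrile or plain hydrogen on this aromatic carbon would also stay within the scatter of compound 3.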